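Working notes: compound 4, fluoro for trifluoromethyl

The compounds below may be only part of what the source reports. "The series", "measured", "known", "first", "only" and "open" are said of these compounds alone.

Measured in an assay on isolated protein for inhibition of DNA topoisomerase 1 (Homo sapiens), with a stated time of 30 min, tested at 100 uM; on this read-out lower numbers stand for a weaker effect and higher numbers for a stronger effect at the one concentration tested:
compound 1 `Cc1ccc2c(=O)[nH]c(-c3ccccc3C)nc2c1` gives 100%
compound 2 `Cc1ccc2c(=O)[nH]c(-c3ccccc3F)nc2c1` gives 81.2%
compound 3 `Cc1ccc2nc(-c3cccc(C(F)(F)F)c3)[nH]c(=O)c2c1` gives 45.8%

Compound 3 stands lowest of the three numbers in this assay; compound 2 is the nearest above it and compound 1 the furthest, both gaps beyond the scatter. Compound 4 `Cc1ccc2nc(-c3cccc(F)c3)[nH]c(=O)c2c1` is compound 3 with one change: fluoro in place of trifluoromethyl on an aromatic carbon.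

For the measured compounds named here, the only measured step is a number 18.8 percentage points lower from compound 1 to compound 2 (beyond the scatter), a modest drop. It brings in fluoro as well, but the group it replaces is methyl, not trifluoromethyl, so it bears on the present step only loosely. Going by the values given here, no measured pair removes a trifluoromethyl, and no measured pair changes compound 3 directly. With one loosely related step pointing downward, and compound 3 already lowest, the expectation is a step of uncertain direction, most likely within the scatter.

The estimate for compound 4 in this assay is 48%, range 22% to 74%. That estimate means an expected step of a number 2.2 percentage points higher from compound 3 to compound 4 (within the scatter).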

Compound 4, a percentage reported as inhibition, at one concentration (the size of the read-out at that concentration, not a potency): 82.9%
Estimate against measurement, compound 4: 34.9 percentage points below; the whole stated range lies below it.
By their numbers in this assay, from the lowest: compound 3; then compounds 2 and 4 (each within the scatter of the next); then compound 1.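

In this assay, fluoro in place of trifluoromethyl on an aromatic carbon, meta to a large group, gives a number 37.1 percentage points higher from compound 3 to compound 4 (beyond the scatter), so the read-out at this position depends strongly on the group it carries. Fluoro entering does not act in one direction across the series: the only other step that brings it in, replacing methyl at a different place, gives a number 18.8 percentage points lower from compound 1 to compound 2 (beyond the scatter). No measurement on hand explains the size of the new step.

The compounds shown leave open how a hydrogen, a chlorine, an amine or a carboxylic acid would read at this position. For the compounds shown here, with only two groups compared here, they also leave open whether the read-out follows the count of heavy atoms in the group or something particular to fluoro.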